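The source may hold more compounds than are shown below. What is called first, only, known or untested is meant among the compounds shown, and "the series" means these compounds.

Measured so far in an ADME assay on SW480 cells (Homo sapiens) for cytotoxicity, read by MTT assay, with a stated time of 72 h; a lower number here means a stronger inhibitor, a higher number a weaker inhibitor:
Compound 1, `CCc1cccc(NC(=O)c2cccc(/C=C3\CC(=O)N(c4ccccc4)C3=O)c2)c1`: compound 1 gives 88600 nM.
Compound 2, `Cc1ccc(NC(=O)c2cccc(/C=C3\CC(=O)N(c4ccccc4)C3=O)c2)cc1`: compound 2 gives only a limit, > 100000 nM.
Compound 3, `O=C(Nc1ccc(F)cc1)c1cccc(/C=C2\CC(=O)N(c3ccccc3)C2=O)c1`: compound 3 gives only a limit, > 100000 nM.

Among the compounds with values here, compound 3 stands at the limit of this assay, where (the limit of > 100000 nM in this assay, at which 2 of the 3 values shown sit); the only read number in the set belongs to compound 1. Compound 4, `CSc1cccc(NC(=O)c2cccc(/C=C3\CC(=O)N(c4ccccc4)C3=O)c2)c1`, is not yet measured. The change from compound 3 is 3-(methylsulfanyl)phenyl in place of 4-fluorophenyl on an amide-type nitrogen.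

Within the data shown here, no measured step replaces the same group. Among the measured compounds shown here, the steps of an at least 1.1-fold higher number from compound 1 to compound 3 (0.05 log units; that floor lies within the scatter) and an at least 1.1-fold higher number from compound 1 to compound 2 (0.05 log units; that floor lies within the scatter) both run from the one read number to a limit, and a step that the two limits leave unreadable from compound 2 to compound 3 cannot be read at all. Every measured variation of the group on the amide-type nitrogen has left the value at or close to the limit, so no step beyond the scatter is expected in this assay from compound 3 to compound 4, in either direction.

Compound 4 is therefore expected at about 100000 nM, estimated within 50000 nM to 300000 nM, with a real chance that only a limit is reported again. The expected step is a number no higher from compound 3 to compound 4 (the limit leaves the size open).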

Compound 4, half-maximal inhibitory concentration: 74300 nM
Beside the measured number, compound 4's estimate is 1.3-fold (0.13 log units) above it, within the range that was stated.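

In this assay, the group 3-(methylsulfanyl)phenyl on the amide-type nitrogen yields a second read number in the set, yet neither an at least 1.3-fold lower number from compound 3 to compound 4 (0.12 log units; that floor lies within the scatter) nor an at least 1.3-fold lower number from compound 2 to compound 4 (0.12 log units; that floor lies within the scatter) shows a real separation from the limit compounds. The first fully read step, a 1.2-fold lower number from compound 1 to compound 4 (0.08 log units; within the scatter), shows that methylsulfanyl in place of ethyl on an aromatic carbon makes no difference beyond the scatter. Both read numbers belong to 3-substituted phenyl groups, while compound 2 and compound 3, with 4-methylphenyl and 4-fluorophenyl, remain at a limit: the limit of > 100000 nM in this assay, at which 2 of the 4 values shown sit.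

Within the data shown here, the step between those two limits cannot be read, and no pair here moves one group from one ring position to another, so the role of position stays open. Also open, on these data alone, is whether an amine or a carboxylic acid on this phenyl ring would bring the values clear of the limit.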